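Compounds 1 to 3: cytotoxicity notes on one aryl swap

This account rests on a few compounds, and the source may have more. Where it says the series, first, only, none or still open, it means among the compounds named here.

Measured in a functional assay on U2OS cells (Homo sapiens) for cytotoxicity, read by MTT assay, with a stated time of 48 h; a higher number here means a weaker inhibitor, a lower number a stronger inhibitor:
- compound 1 `Fc1cccc(-c2nc(Nc3ccccc3F)c3cc(F)ccc3n2)c1`: > 50000 nM (a limit)
- compound 2 `Nc1ccc(Nc2nc(-c3cccc(F)c3)nc3ccc(F)cc23)cc1`: 44200 nM

Not yet measured: compound 3 `Cc1ccccc1Nc1nc(-c2cccc(F)c2)nc2ccc(F)cc12`.

Among the compounds with values here, compound 2 holds the only true number in this assay, 44200 nM. Compound 1 is reported only as a limit, > 50000 nM. The next change is 2-methylphenyl in place of 4-aminophenyl on a nitrogen on an aromatic ring.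

Within the data shown here, one measured step bears on this: an at least 1.1-fold lower number from compound 1 to compound 2 (0.05 log units; that floor lies within the scatter). It is a floor rather than a size, and it also swaps out a 4-aminophenyl, in the opposite direction. The other relevant reference is the limit of > 50000 nM in this assay, at which 1 of the 2 values shown sits. Little movement is therefore expected, with no shift beyond the scatter. The expected step is a 1.1-fold higher number from compound 2 to compound 3 (0.05 log units; within the scatter). Compound 3 is estimated at 50000 nM, with an expected range of 25000 nM to 100000 nM. A report of compound 3 as a limit is also quite possible.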

Compound 3, half-maximal inhibitory concentration: > 50000 nM
Compound 3: only a limit was reported (the forecaster's own chance of this, stated with the estimate: 60%); the middle value sits exactly at the limit.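

In this assay, 2-methylphenyl in place of 4-aminophenyl on this nitrogen gives an at least 1.1-fold higher number from compound 2 to compound 3 (0.05 log units; that floor lies within the scatter), so the change has only a floor and no readable size. The entering group has 0 hydrogen-bond donors and 0 hydrogen-bond acceptors, and compound 3 is reported only as a limit, while the step from compound 1 to compound 3 cannot be read. Within the data shown here, compound 2, at 44200 nM, is still the only true number. The series is now mostly bounded by the limit: the limit of > 50000 nM in this assay, at which 2 of the 3 values shown sit.

The compounds shown leave open how far the number can fall with other groups on this nitrogen, such as a phenyl carrying a carboxylic acid or a longer amine chain. They also leave open the true sizes of the steps that end at a limit.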